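Working notes: aryl change from compound 2 to compound 3

A few compounds are considered here, and "the series" means these few. Any claim that something is new, unique, unknown or untested is made for them only; others in the source may bear on it.

- compound 1 `NS(=O)(=O)c1ccc(N2N=C(c3ccc(Oc4ccccc4)cc3)CC2c2cccc(F)c2)cc1` gives 25000 nM
- compound 2 `Cc1ccc(C2CC(c3ccc(Oc4ccccc4)cc3)=NN2c2ccc(S(N)(=O)=O)cc2)cc1` gives 7200 nM

In an ADME assay on MT4 cells (Homo sapiens) for cytotoxicity, read by MTT assay, with a stated time of 96 h (on this read-out lower numbers stand for higher toxicity in this test and higher numbers for lower toxicity in this test), compound 2 stands lowest of the two, at 7200 nM on this read-out. Compound 3 `NS(=O)(=O)c1ccc(N2N=C(c3ccc(Oc4ccccc4)cc3)CC2c2cccc(Cl)c2)cc1` is next, with the change 3-chlorophenyl in place of 4-methylphenyl on a saturated ring carbon on a saturated ring carbon. Going by the values given here, one measured step bears on it, and this step is a 3.5-fold lower number from compound 1 to compound 2 (0.54 log units; beyond the scatter) and so modest but beyond the scatter. That step brought in 4-methylphenyl in place of 3-fluorophenyl. Compound 3 removes the same 4-methylphenyl, and its 3-chlorophenyl differs in name from the 3-fluorophenyl of compound 1 only by the halogen. Among the compounds with values here, no measured step compares those two groups. Most of that step is therefore expected to reverse in this assay with a 2.1-fold higher number from compound 2 to compound 3 (0.32 log units; beyond the scatter) as the estimated step. Compound 3 is estimated at 15000 nM with an expected range from 7000 nM to 32000 nM in this test.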

Compound 3, half-maximal cytotoxic concentration: 8000 nM
Compound 3: middle estimate off by 1.9-fold (0.27 log units), on the high side, and the stated range covers the measured number.
By their numbers in this assay, from the lowest: compounds 2 and 3 (each within the scatter of the next); then compound 1.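

In this assay, the step at the saturated ring carbon gives a 1.1-fold higher number from compound 2 to compound 3 (0.05 log units; within the scatter), so 3-chlorophenyl and 4-methylphenyl are not separated at this position. Going by these compounds alone, the halogen change, which the earlier compounds did not cover, gives a 3.1-fold lower number from compound 1 to compound 3 (0.49 log units; beyond the scatter), so with chloro in place of fluoro on the aromatic carbon, the read-out does respond to the halogen, and the 3-fluorophenyl of compound 1 stands apart from both other groups. Nothing measured here bears on the reason for these steps.

The compounds shown leave open how an unsubstituted phenyl, or a phenyl bearing an amine or a carboxylic acid, would read at this saturated ring carbon. They also leave open whether the gap seen with 3-fluorophenyl extends to bromo in place of chloro on the same aromatic carbon.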